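From nitro to amino: an estimate for compound 4

This account rests on a few compounds, and the source may have more. Where it says the series, first, only, none or still open, it means among the compounds named here.

Values so far in a functional assay on ECa-109 cells (Homo sapiens) for cytotoxicity, read by MTT assay, with a stated time of 48 h; a lower number here means a stronger inhibitor, a higher number a weaker inhibitor
- compound 1 `COc1cc(-n2c(-c3ccc(Br)cc3)cn(C(C)=O)c2=O)cc(OC)c1OC` gives 3800 nM in this assay
- compound 2 `COc1cc(-n2c(-c3ccc(F)cc3F)cn(C(C)=O)c2=O)cc(OC)c1OC` gives > 50000 nM as a limit, not a number
- compound 3 `COc1ccc(-c2cn(C(C)=O)c(=O)n2-c2cc(OC)c(OC)c(OC)c2)cc1[N+](=O)[O-]` gives 30800 nM in this assay

Compound 3 at 30800 nM holds the higher of the two exact numbers, and compound 1 at 3800 nM sits lower, a gap beyond the scatter. The value for compound 2 is only a limit.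

Compound 4 `COc1ccc(-c2cn(C(C)=O)c(=O)n2-c2cc(OC)c(OC)c(OC)c2)cc1N` carries amino in place of nitro on an aromatic carbon, ortho to a methoxy group. Within the data shown here, the only measured step is an at least 13-fold higher number from compound 1 to compound 2 (1.11 log units; beyond the scatter) and it is large, with 2,4-difluorophenyl in place of 4-bromophenyl. It involves neither nitro nor amino, so it bears only indirectly, showing that a swap on an aromatic carbon can move the number far. Compound 1 at 3800 nM shows that lower numbers are reachable with this shared core, so a sizeable move toward a lower number is expected in this assay, though with much uncertainty. The expected change is a 5.1-fold lower number from compound 3 to compound 4 (0.71 log units; beyond the scatter) as an estimate. For compound 4 the estimated value is 6000 nM with an expected range from 700 nM to 40000 nM in this assay.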

Compound 4, half-maximal inhibitory concentration: > 50000 nM
Compound 4: only a limit was reported (the forecaster's own chance of this, stated with the estimate: 10%); middle value at least 8.3-fold (0.92 log units) away from the limit.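

At this position, ortho to a methoxy group, amino in place of nitro brings no lower number in this assay, and the step reads an at least 1.6-fold higher number from compound 3 to compound 4 (0.21 log units; that floor lies within the scatter). That floor leaves open whether the change makes any real difference, so compound 3 and compound 4 cannot be ranked. The wider comparison is clearer, with an at least 13-fold higher number from compound 1 to compound 4 (1.11 log units; beyond the scatter), so 3-amino-4-methoxyphenyl falls well short of 4-bromophenyl on the shared core. The reading for compound 4 is a limit and not a number, and the step to compound 2 cannot be read, as the same limit applies to both: the limit of > 50000 nM in this assay, at which 2 of the 4 values shown sit.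

From the compounds shown here alone, whether a hydroxyl, a nitrile or an acetamide at this position would give a lower number remains open. Also open, going by these compounds, is how weak compound 4 really is, since the limit gives no exact value.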